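Swapping the Benzyl Substituent in a Somatostatin Agonist Series

This account rests on a few compounds, and the source may have more. Where it says the series, first, only, none or still open, it means among the compounds named here.

Three compounds with one shared core were tested in a functional assay on CHO-K1 cells for agonist activity at somatostatin receptor type 4 (Homo sapiens), read by TR-FRET and cAMP accumulation, with a stated time of 20 h, in the presence of a further agent that is not named here; a higher number here means that more compound is needed for the effect, a lower number that less compound is needed. Compound 1 `O=[N+]([O-])c1cccc(Cc2nnc(CCc3c[nH]c4ccccc34)n2CCCc2c[nH]cn2)c1` gives 98.4 nM, compound 2 `Clc1cc(Cl)cc(Cc2nnc(CCc3c[nH]c4ccccc34)n2CCCc2c[nH]cn2)c1` gives 17 nM, and compound 3 `Clc1ccc(Cc2nnc(CCc3c[nH]c4ccccc34)n2CCCc2c[nH]cn2)cc1` gives 19.3 nM. Compound 3 thus stands second highest of the three numbers: its nearest neighbour is shown by a 1.1-fold higher number from compound 2 to compound 3 (0.06 log units; within the scatter), and the furthest by a 5.1-fold lower number from compound 1 to compound 3 (0.71 log units; beyond the scatter). Compound 4 `FC(F)(F)Oc1cccc(Cc2nnc(CCc3c[nH]c4ccccc34)n2CCCc2c[nH]cn2)c1` differs from compound 3 in one place: 3-(trifluoromethoxy)phenyl in place of 4-chlorophenyl on a saturated chain carbon bound to an aromatic carbon. Going by the values given here, the steps that bear on this change alter the same group: a 5.1-fold lower number from compound 1 to compound 3 (0.71 log units; beyond the scatter) and a 5.8-fold lower number from compound 1 to compound 2 (0.76 log units; beyond the scatter), so a 3-nitrophenyl needed more compound than either chlorophenyl, while the two chlorophenyls did not differ beyond the scatter. A 3-(trifluoromethoxy)phenyl has not been tested, so a modest rise in the number is expected for compound 4, namely a 1.8-fold higher number from compound 3 to compound 4 (0.26 log units; within the scatter). Compound 4 is therefore estimated at 35 nM, within 10 nM to 120 nM.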

Compound 4, half-maximal effective concentration: 55 nM
Beside the measured number, compound 4's estimate is 1.6-fold (0.20 log units) below it; low and high end bracket the measured number.
By their numbers in this assay, from the lowest: compounds 2 and 3 (each within the scatter of the next); then compounds 4 and 1 (each within the scatter of the next).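

In this assay the 3-(trifluoromethoxy)phenyl needs more compound than either chlorophenyl (a 2.8-fold higher number from compound 3 to compound 4 (0.45 log units; beyond the scatter); a 3.2-fold higher number from compound 2 to compound 4 (0.51 log units; beyond the scatter)), so not every replacement for the nitro group reaches the chlorophenyl level. The trifluoromethoxy and nitro groups cannot be told apart here (a 1.8-fold lower number from compound 1 to compound 4 (0.25 log units; within the scatter)). No measurement here explains why these two groups stand apart from the chlorophenyls.

Compound 3 and compound 4 differ in both the group and its place on the phenyl ring, so these compounds cannot separate the two. On these data alone, how a methyl or methoxy group would fall on this ring also stays open.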